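The compounds below may be only part of what the source reports. "The series", "measured", "known", "first", "only" and "open" are said of these compounds alone.

Measured in an ADME assay on a cell-free system (plasma, Homo sapiens) for metabolic stability, with a stated time of 90 min; a higher number here means that more of the compound is left, a lower number that less of the compound is left:

compound 1 `CCCC(=O)OCCCCCC(=O)N[C@H](C(=O)N1C[C@H](O)C[C@H]1C(=O)NCc1ccc(-c2scnc2C)cc1)C(C)(C)C`: 13%
compound 2 `CCCC(=O)NCCCCCC(=O)N[C@H](C(=O)N1C[C@H](O)C[C@H]1C(=O)NCc1ccc(-c2scnc2C)cc1)C(C)(C)C`: 83%
compound 3 `COCC(=O)NCCCCCC(=O)N[C@H](C(=O)N1C[C@H](O)C[C@H]1C(=O)NCc1ccc(-c2scnc2C)cc1)C(C)(C)C`: 126%

Compound 3 stands highest of the three, and its gaps to both others lie beyond the scatter. Compound 4 `COCC(=O)OCCCCCC(=O)N[C@H](C(=O)N1C[C@H](O)C[C@H]1C(=O)NCc1ccc(-c2scnc2C)cc1)C(C)(C)C` differs from it in one place: ((methoxymethyl)carbonyl)oxy in place of ((methoxymethyl)carbonyl)amino on a saturated chain carbon, five bonds along the chain from a carbonyl carbon. In words, ((methoxymethyl)carbonyl)oxy sits in place of ((methoxymethyl)carbonyl)amino on a saturated chain carbon, five bonds along the chain from a carbonyl carbon.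

Among the compounds with values here, the closest precedent is the same exchange of oxy and amino on a propylcarbonyl group, run in the opposite direction: a number 70 percentage points higher from compound 1 to compound 2 (beyond the scatter). Exchanging ethyl for methoxy among the amino compounds gave a number 43 percentage points higher from compound 2 to compound 3 (beyond the scatter), and the two changes together gave a number 113 percentage points higher from compound 1 to compound 3 (beyond the scatter). The size of the methoxy change among the oxy compounds has not been measured. A large drop is therefore expected, and the estimated step is a number 106 percentage points lower from compound 3 to compound 4 (beyond the scatter). Compound 4 is estimated at 20%, with an expected range from 3% to 50%.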

Compound 4, percent of the compound remaining: 1%
Compound 4: the middle estimate sits 19 percentage points above what was measured, outside the stated range (below it).
By their numbers in this assay, from the lowest: compound 4; then compound 1; then compound 2; then compound 3.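

Replacing the amino link with the oxy link at this place on the chain now proves damaging with a second acyl group: in this assay there is a number 125 percentage points lower from compound 3 to compound 4 (beyond the scatter), and ((methoxymethyl)carbonyl)oxy in place of (propylcarbonyl)amino gives a number 82 percentage points lower from compound 2 to compound 4 (beyond the scatter). Methoxy in place of ethyl does not rescue the oxy compounds, since it gives a number 12 percentage points lower from compound 1 to compound 4 (beyond the scatter). So the effect of that exchange depends on the link that carries it, and its direction reverses: the same change on two cores in this assay, a number 43 percentage points higher (beyond the scatter) from compound 2 to compound 3 and a number 12 percentage points lower (beyond the scatter) from compound 1 to compound 4, 55 percentage points apart, beyond the scatter of two such steps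

The compounds shown leave open how a urea or a carbamate would fare at this place, and whether a longer chain carrying these groups would keep the same gap between the amino and oxy forms. They also do not show what compound 4 turns into as it disappears.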